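The compounds below may be only part of what the source reports. "The series", "measured", "known", "first", "only" and "open" are said of these compounds alone.

Among the compounds with values here, compound 2 `Cc1nc(-c2ccccc2NCC2=NCCN2)co1` holds the higher of the two numbers measured so far in a functional assay for activation of Alpha-1A adrenergic receptor (Homo sapiens), read by calcium flux; a lower number here means that less compound is needed, a higher number that more compound is needed for the effect: compound 2 gives 324 nM, whereas compound 1 `Cc1ncc(-c2ccccc2NCC2=NCCN2)o1` gives 110 nM. Within the data shown here, the only measured step is a 2.9-fold higher number from compound 1 to compound 2 (0.47 log units; beyond the scatter), a modest move that came from rearranging the same five-membered ring on the shared core. Compound 3 `Cc1cc(-c2ccccc2NCC2=NCCN2)on1` is not yet measured; it differs from compound 2 by 3-methyl-1,2-oxazol-5-yl in place of 2-methyl-1,3-oxazol-4-yl on an aromatic carbon, once more a reshuffling of the same atoms within the five-membered ring, with no change in size, donors or acceptors. Given that the comparable rearrangement from compound 1 to compound 2 stayed modest, a step of similar size is expected here, most likely back toward the number of compound 1, so compound 3 is estimated to move by a 2.0-fold lower number from compound 2 to compound 3 (0.31 log units; beyond the scatter). Compound 3 is therefore expected at 160 nM, with a plausible range from 60 nM to 450 nM.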

Compound 3, half-maximal effective concentration: 38.9 nM
Estimate against measurement, compound 3: 4.1-fold (0.61 log units) above, outside the stated range (below it).
By their numbers in this assay, from the lowest: compound 3; then compound 1; then compound 2.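

In this assay, the change from 2-methyl-1,3-oxazol-4-yl to 3-methyl-1,2-oxazol-5-yl gives an 8.3-fold lower number from compound 2 to compound 3 (0.92 log units; beyond the scatter), so the arrangement of the ring atoms alone can shift the number at this position, with heavy atoms, donors and acceptors unchanged. The same group also goes past 2-methyl-1,3-oxazol-5-yl, with a 2.8-fold lower number from compound 1 to compound 3 (0.45 log units; beyond the scatter); with both steps beyond the scatter, compound 3 holds the lowest number of the three and the earlier pair does not mark the low end for this ring. No data at hand bear on what lies behind these differences.

Open, on these data alone, is whether this order of rings extends to a thiazole or a 1,2,4-oxadiazole. Also open, as far as these compounds go, is how the number responds to an ethyl or a trifluoromethyl in place of the methyl on 3-methyl-1,2-oxazol-5-yl.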